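The compounds below may be only part of what the source reports. "The series", "measured", "known", "first", "only" and "open" are said of these compounds alone.

Of the compounds shown here, three with a shared core have been tested in a functional assay (strain AB) with Danio rerio as the target, read by microscopy, with a stated time of 1 h; on this read-out lower numbers stand for an effect already at smaller amounts and higher numbers for an effect only at larger amounts of compound. Compound 1 `CCN1CCc2c(sc(NC=O)c2C(N)=O)C1` reads > 25000 nM, which is a limit of the assay and not a number. Compound 2 `CCN1CCc2c(sc(NC(=O)Nc3cccc(C)c3)c2C(N)=O)C1` gives 13000 nM, and compound 3 `CCN1CCc2c(sc(NC(=O)Nc3ccc(I)cc3)c2C(N)=O)C1` gives 1620 nM, the lowest number of the three. The gap to its nearest measured neighbour is an 8.0-fold lower number from compound 2 to compound 3 (0.90 log units; beyond the scatter).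

Compound 4 `CCN1CCc2c(sc(NC(=O)[C@@H]3CCCN3)c2C(N)=O)C1` keeps the core and the carbonyl but replaces the group on that carbonyl: pyrrolidin-2-yl in place of (4-iodophenyl)amino on a carbonyl carbon. Pyrrolidin-2-yl thus takes the place of (4-iodophenyl)amino on a carbonyl carbon. The measured steps that bear on this change act at the same place. One is an at least 15-fold lower number from compound 1 to compound 3 (1.18 log units; beyond the scatter), and the other is an at least 1.9-fold lower number from compound 1 to compound 2 (0.28 log units; that floor lies within the scatter). The step of an 8.0-fold lower number from compound 2 to compound 3 (0.90 log units; beyond the scatter) shows that the choice of aromatic group also matters here.

Among the measured compounds shown here, no tested compound carries pyrrolidin-2-yl, so any forecast is loose. The (4-iodophenyl)amino group came with the large step of an at least 15-fold lower number from compound 1 to compound 3 (1.18 log units; beyond the scatter), and it is the group that leaves, so a move towards higher numbers is expected in this assay. The expected change is a 7.4-fold higher number from compound 3 to compound 4 (0.87 log units; beyond the scatter). Compound 4 is estimated at 12000 nM, with an expected range from 3500 nM to 30000 nM.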

Compound 4, half-maximal effective concentration: > 25000 nM
Compound 4 gave a limit, no number; the forecaster's own chance of this, stated with the estimate: 35%; middle value at least 2.0-fold (0.31 log units) away from the limit.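

In this assay compound 4 gives > 25000 nM, which is a limit of the assay and not a number. Even without an exact value, the change at this carbonyl carbon is readable: putting pyrrolidin-2-yl in place of (4-iodophenyl)amino gives an at least 15-fold higher number from compound 3 to compound 4 (1.18 log units; beyond the scatter), so a ring carrying a nitrogen does not keep the low number of compound 3, and the earlier gain from (4-iodophenyl)amino does not extend to every ring placed here. The comparison with the other aromatic group is less firm: an at least 1.9-fold higher number from compound 2 to compound 4 (0.28 log units; that floor lies within the scatter) has a floor within the scatter, so it does not by itself separate pyrrolidin-2-yl from (3-methylphenyl)amino.

From the compounds shown here alone, whether pyrrolidin-2-yl differs at all from the hydrogen of compound 1 stays open, and that step cannot be read because both compounds sit at the same limit: the limit of > 25000 nM in this assay, at which 2 of the 4 values shown sit. It also remains open whether the aromatic ring alone matters or its linking nitrogen as well, which a phenyl group set directly on the carbonyl, or an open-chain amine such as diethylamino, would help to separate.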